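This account rests on a few compounds, and the source may have more. Where it says the series, first, only, none or still open, it means among the compounds named here.

Compound 3 `Cc1cc(C2=NNC(c3ccc(N4CCCCC4)cc3)C2)c(C)s1` gives the highest number of the three measured compounds in an ADME assay on Vero cells (Chlorocebus sabaeus) for cytotoxicity, with a stated time of 5 days (a lower number here means a stronger inhibitor, a higher number a weaker inhibitor), at 83400 nM. Compound 2 `c1cc(C2=NNC(c3ccc(N4CCCCC4)cc3)C2)cs1` gives 29500 nM, and compound 1 `c1csc(C2=NNC(c3ccc(N4CCCCC4)cc3)C2)c1` gives 3200 nM. The steps of a 9.2-fold higher number from compound 1 to compound 2 (0.96 log units; beyond the scatter) and a 26-fold higher number from compound 1 to compound 3 (1.42 log units; beyond the scatter) and a 2.8-fold higher number from compound 2 to compound 3 (0.45 log units; beyond the scatter) all run toward weaker inhibition as the thiophene changes. Compound 4 `Clc1cc(C2=NNC(c3ccc(N4CCCCC4)cc3)C2)c(Cl)s1` carries 2,5-dichlorothiophen-3-yl in place of 2,5-dimethylthiophen-3-yl on a carbon with a double bond to nitrogen. Among the compounds with values here, no measured step exchanges methyl for chlorine on this ring, so the two steps ending at compound 3 give only a loose guide. In this assay compound 4 is therefore expected to stay near compound 3, with no step beyond the scatter firmly expected. Compound 4 is estimated at 60000 nM, within 20000 nM to 160000 nM. The expected step is a 1.4-fold lower number from compound 3 to compound 4 (0.14 log units; within the scatter).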

Compound 4, half-maximal inhibitory concentration: 53900 nM
Estimate against measurement, compound 4: 1.1-fold (0.05 log units) above; low and high end bracket the measured number.
By their numbers in this assay, from the lowest: compound 1; then compounds 2, 4 and 3 (each within the scatter of the next, the first and the last beyond it).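

In this assay, chlorine in place of methyl at both ring places leaves the number within the scatter (a 1.5-fold lower number from compound 3 to compound 4 (0.19 log units; within the scatter)). The 2,5-dichlorothiophen-3-yl group is also not separated from the unsubstituted thiophen-3-yl group (a 1.8-fold higher number from compound 2 to compound 4 (0.26 log units; within the scatter)), whereas the gap to thiophen-2-yl remains beyond the scatter (a 17-fold higher number from compound 1 to compound 4 (1.23 log units; beyond the scatter)), so compound 4 sits apart only from compound 1. Nothing available offers an explanation for this result. On these data alone, whether methyl or chlorine on thiophen-2-yl would shift the number of compound 1 remains open. So does the effect of an amine or a carboxylic acid on the thiophene.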